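Sulfonyl aryl para-substituent change in the piperazinyl series

The source may hold more compounds than are shown below. What is called first, only, known or untested is meant among the compounds shown, and "the series" means these compounds.

Compound 1 `CCN(CC)c1ccc2cc(C(=O)c3ccc(N4CCN(C(=O)CN5CCNCC5)CC4)cc3)oc2c1` carries an unsubstituted terminal piperazine; in a functional assay on HeLa cells (Homo sapiens) for cytotoxicity, read by MTT assay, with a stated time of 48 h (a lower number here means a stronger inhibitor, a higher number a weaker inhibitor), compound 1 gives 1350 nM. Compound 2 `CCN(CC)c1ccc2cc(C(=O)c3ccc(N4CCN(C(=O)CN5CCN(S(=O)(=O)c6ccc(OC(F)(F)F)cc6)CC5)CC4)cc3)oc2c1` adds a 4-(trifluoromethoxy)phenylsulfonyl group on that piperazine; in this assay compound 2 gives 30200 nM. Compound 3 `CCN(CC)c1ccc2cc(C(=O)c3ccc(N4CCN(C(=O)CN5CCN(S(=O)(=O)c6ccc(C(F)(F)F)cc6)CC5)CC4)cc3)oc2c1` carries the trifluoromethyl analogue of that sulfonyl aryl group. In this assay compound 3 reaches only the limit of the assay, > 40000 nM, so no number is known for it. The step of an at least 1.3-fold higher number from compound 2 to compound 3 (0.12 log units; that floor lies within the scatter) is bounded by the limit of > 40000 nM in this assay, at which 1 of the 3 values shown sits. Compound 4 `CCN(CC)c1ccc2cc(C(=O)c3ccc(N4CCN(C(=O)CN5CCN(S(=O)(=O)c6ccc(C#N)cc6)CC5)CC4)cc3)oc2c1` differs from compound 3 by cyano in place of trifluoromethyl on an aromatic carbon. Going by the values given here, the only measured step at this position, an at least 1.3-fold higher number from compound 2 to compound 3 (0.12 log units; that floor lies within the scatter), shows that two different groups on this ring both sit well away from compound 1, so a change within the scatter is expected in this assay from compound 3 to compound 4. The expected step is a number no higher from compound 3 to compound 4 (the limit leaves the size open). Compound 4 is expected to give about 40000 nM, between 15000 nM and 100000 nM, with a fair chance that only the limit is reported.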

Compound 4, half-maximal inhibitory concentration: 8470 nM
Compound 4: middle estimate off by 4.7-fold (0.67 log units), on the high side, outside the stated range (below it).
By their numbers in this assay, from the lowest: compound 1; then compound 4; then compound 2. At a limit, above all of these: compound 3.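

The group on the aromatic carbon para to a large group matters in this assay, as changes here can go beyond the scatter: cyano in place of trifluoromethyl gives an at least 4.7-fold lower number from compound 3 to compound 4 (0.67 log units; beyond the scatter), and cyano in place of trifluoromethoxy gives a 3.6-fold lower number from compound 2 to compound 4 (0.55 log units; beyond the scatter). The first of these is only a floor, since the value of compound 3 is a limit and not a number: the limit of > 40000 nM in this assay, at which 1 of the 4 values shown sits. Even so, the (4-cyanophenyl)sulfonyl group on the amine nitrogen gives a 6.3-fold higher number from compound 1 to compound 4 (0.80 log units; beyond the scatter), so compound 4 does not recover the number of compound 1.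

Going by these compounds alone, with only three groups compared at this place, one of them at a limit, what in the cyano group accounts for the lower number stays unresolved. A carboxylic acid, an amine or a plain hydrogen at this place would show whether the number can come closer to that of compound 1.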